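The source may report more compounds than this note shows. Statements on the series, on what has been measured and on what is new or still open speak of the compounds shown alone.

In an in vitro ADME assay on microsomes (Rattus norvegicus) for metabolic stability (a higher number here means that the compound lasts longer, a lower number that the compound disappears faster), compound 1 `CCc1nc(N(CC2CC2)CC2CC2)c(CC)nc1-c1ccc(Cl)cc1Cl` gives < 0.0167 h, a limit and not a number. Compound 2 `CCc1nc(-c2ccc(C)cc2OC)c(CC)nc1NC(CC)CC` gives < 0.0167 h, also a limit. Compound 3 `CCc1nc(-c2cnc(C)cc2N(C)C)c(CC)nc1NC(CC)CC` gives < 0.0167 h, again a limit. Compound 1 therefore stands at the limit of < 0.0167 h in this assay, at which 3 of the 3 values shown sit, and the series offers no measured number to place it against.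

Compound 4 `CCc1nc(-c2ccc(Cl)cc2Cl)c(CC)nc1SC(C)CC` keeps the core of compound 1 and carries (sec-butyl)sulfanyl in place of bis(cyclopropylmethyl)amino on an aromatic carbon. For the measured compounds named here, no two measured compounds differ in one place only, so the series gives no direct size for this change. The expectation starts from compound 1 at < 0.0167 h, a limit that compound 2 and compound 3 share despite their different substituents. An estimated step that the limit leaves unreadable from compound 1 to compound 4 is expected, which means no change beyond the scatter and no firm direction. For compound 4 the expected value is 0.015 h, with an estimated range from 0.008 h to 0.05 h.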

Compound 4, half-life: 0.0683 h
The estimate for compound 4 lay 4.6-fold (0.66 log units) below the measured number, and the stated range ends below it.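

In this assay compound 4 gives 0.0683 h, the only value among the compounds shown that is a number and not a limit. On this aromatic carbon next to the ring nitrogen, (sec-butyl)sulfanyl in place of bis(cyclopropylmethyl)amino gives an at least 4.0-fold higher number from compound 1 to compound 4 (0.61 log units; beyond the scatter), so the group at this position can move the half-life beyond the scatter, and the step is a minimum size since one of its ends is a limit. The other compounds give no number to set beside compound 4: the limit of < 0.0167 h in this assay, at which 3 of the 4 values shown sit.

Going by these compounds, the swap changes the whole group at once, so it remains open whether the sulfur or the loss of the two cyclopropylmethyl arms carries the step. A sec-butoxy group at the same position, with the 2,4-dichlorophenyl group kept, would separate these two readings.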